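Isopropyl in place of cyclobutyl on the quaternary nitrogen

The compounds below may be only part of what the source reports. "The series", "measured", "known", "first", "only" and "open" are said of these compounds alone.

Compound 1, `C[N+](C)(CCCC(=O)[O-])C1CCC1`: 810 nM
Compound 2, `C[N+](C)(CCCC(=O)[O-])C1CCCC1`: > 1000000 nM

For the measured compounds named here, in an assay for inhibition of gamma-butyrobetaine dioxygenase (Homo sapiens), read by HPLC, with stated times of 15 min and 30 min (on this read-out higher numbers stand for weaker inhibition and lower numbers for stronger inhibition), compound 1 gives 810 nM, the only number among the two values shown. For compound 2 this assay reports only a limit, > 1000000 nM, one of the two values here (the limit of > 1000000 nM in this assay, at which 1 of the 2 values shown sits). Compound 3, `CC(C)[N+](C)(C)CCCC(=O)[O-]`, differs from compound 1 by isopropyl in place of cyclobutyl on an amine nitrogen. Going by the values given here, no measured pair shows this change, so its size is uncertain; a step beyond the scatter towards weaker inhibition is expected. Compound 3 is therefore expected to give 2500 nM, within 400 nM to 30000 nM. This expectation means a step of a 3.1-fold higher number from compound 1 to compound 3 (0.49 log units; beyond the scatter).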

Compound 3, half-maximal inhibitory concentration: 5700 nM
For compound 3 the middle estimate is 2.3-fold (0.36 log units) below the measured one; measured number inside the range.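

Replacing the ring with isopropyl on an amine nitrogen gives a 7.0-fold higher number from compound 1 to compound 3 (0.85 log units; beyond the scatter) in this assay, so a measured number at this position does not depend on the cyclobutyl ring, although the number is higher without it. Compound 2 alone among the three remains a limit of the assay: the limit of > 1000000 nM in this assay, at which 1 of the 3 values shown sits.

What the compounds shown leave open is how ethyl or cyclopropyl would read at this position. As far as these compounds go, whether the step from cyclobutyl to isopropyl would hold with a longer chain in place of the butyrate chain also stays open.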